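Fluoro for chloro on the nitrochromene core

The compounds below may be only part of what the source reports. "The series", "measured", "known", "first", "only" and "open" are said of these compounds alone.

Compound 1, `O=[N+]([O-])C1=Cc2cccc(I)c2OC1C(F)(F)F`, in an assay on 1321N1 cells for antagonist activity at P2Y purinoceptor 6 (Homo sapiens), read by FLIPR and calcium flux (a lower number here means a stronger inhibitor, a higher number a weaker inhibitor), gives 4090 nM.
Compound 2, `O=[N+]([O-])C1=Cc2cc(Cl)ccc2OC1C(F)(F)F`, in this assay gives 1790 nM.
Compound 3, `CC[Si](C#Cc1cccc2c1C=C([N+](=O)[O-])C(C(F)(F)F)O2)(CC)CC`, in this assay gives 4770 nM.

Three measured compounds share a core that carries a nitro group and a trifluoromethyl group, and differ only in the substituent on the carbocyclic aromatic ring. Compound 2 stands lowest of the three numbers, and both its neighbours lie beyond the usual scatter: compound 1 sits at a higher number, and compound 3 sits higher still. On these three numbers compound 2 is therefore the strongest inhibitor of the set.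

The unmeasured compound 4, `O=[N+]([O-])C1=Cc2cc(F)ccc2OC1C(F)(F)F`, is built from compound 2 by a single change: fluoro in place of chloro on an aromatic carbon. Among the compounds with values here, no pair of measured compounds shows this same exchange, so no measured step can be carried over directly.

In this assay the step from compound 2 to compound 4 is expected to be modest and to run towards a higher number, though a result within the scatter would not surprise. Compound 4 is estimated at 3000 nM, with a range from 1200 nM to 8000 nM; this estimate means a step of a 1.7-fold higher number from compound 2 to compound 4 (0.22 log units; within the scatter).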

Compound 4, half-maximal inhibitory concentration: 1150 nM
Compound 4: middle estimate off by 2.6-fold (0.42 log units), on the high side; the whole stated range lies above it.
By their numbers in this assay, from the lowest: compounds 4 and 2 (each within the scatter of the next); then compounds 1 and 3 (each within the scatter of the next).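

In this assay, within the data shown here, fluoro in place of chloro gives a 1.6-fold lower number from compound 2 to compound 4 (0.19 log units; within the scatter), the first step between two measured compounds that differ in one place. It shows that on this aromatic carbon, meta to a fused ring and para to a fused ring, the two halogens cannot be told apart, since the step stays within the scatter, and compound 4 joins compound 2 at the low-number end of the series without a clear order between them. Nothing available bears on why the two substituents read alike in this assay.

What the compounds shown leave open is whether this carbon responds at all to a change larger than one halogen for another: a methoxy group, an amine, a carboxylic acid or a longer chain in the same place, or plain hydrogen there, might give a step beyond the scatter or might not. Compound 1 and compound 3 cannot settle this, as each differs from compound 2 and compound 4 in more than one place and so gives no readable step to either.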